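Dimethoxy replaces amino on the pendant phenyl ring

The source may report more compounds than this note shows. Statements on the series, on what has been measured and on what is new or still open speak of the compounds shown alone.

Measured compounds:
compound 1 `COc1ccc(Oc2ccccc2NC(C)=C2C(=O)CC(c3ccccc3)CC2=O)cc1`: 83 nM
compound 2 `CC(Nc1ccccc1Oc1ccccc1)=C1C(=O)CC(c2ccccc2)CC1=O`: 160 nM
compound 3 `CC(Nc1ccccc1Oc1cccc(N)c1)=C1C(=O)CC(c2ccccc2)CC1=O`: 41 nM

In a functional assay on HMEC-1 cells (Homo sapiens) for antiproliferative activity, read by cell counting, with a stated time of 4 days (on this read-out higher numbers stand for weaker inhibition and lower numbers for stronger inhibition), compound 3 gives the lowest number of the three, with compound 1 nearest and compound 2 furthest. Compound 4 `COc1ccc(Oc2ccccc2NC(C)=C2C(=O)CC(c3ccccc3)CC2=O)cc1OC` differs from compound 3 by 3,4-dimethoxyphenyl in place of 3-aminophenyl on an oxygen on an aromatic ring. Within the data shown here, two steps bear on this. Adding amino gave a 3.9-fold lower number from compound 2 to compound 3 (0.59 log units; beyond the scatter), while adding methoxy gave only a 1.9-fold higher number from compound 1 to compound 2 (0.29 log units; within the scatter) in reverse, and exchanging the whole ring gave a 2.0-fold lower number from compound 1 to compound 3 (0.31 log units; beyond the scatter). Losing the amino therefore points to a somewhat higher number, partly offset by the second methoxy. Compound 4 is expected at 65 nM, with a range from 25 nM to 160 nM, meaning an estimated step of a 1.6-fold higher number from compound 3 to compound 4 (0.20 log units; within the scatter).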

Compound 4, half-maximal inhibitory concentration: 140 nM
Beside the measured number, compound 4's estimate is 2.2-fold (0.33 log units) below it; the range from low to high includes it.
By their numbers in this assay, from the lowest: compound 3; then compounds 1, 4 and 2 (each within the scatter of the next).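

The 3,4-dimethoxyphenyl ring gives up what the 3-aminophenyl ring gained, with a 3.4-fold higher number from compound 3 to compound 4 (0.53 log units; beyond the scatter) and so far only the amino compound stands apart. Against the plain phenyl ring, the same ring shows a 1.1-fold lower number from compound 2 to compound 4 (0.06 log units; within the scatter) and the second methoxy shows a 1.7-fold higher number from compound 1 to compound 4 (0.23 log units; within the scatter) so these methoxy groups do not separate from having none. No measurement shown explains the amino group's standing.

From the compounds shown here alone, whether a hydroxyl, a dimethylamino or an acetamido group could take the amino group's place and keep the low number remains open.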